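This account rests on a few compounds, and the source may have more. Where it says the series, first, only, none or still open, it means among the compounds named here.

Values in a functional assay on the whole organism (strain Wistar) for inhibition, with Rattus norvegicus as the target, with stated times of 30 min and 3 h, at a dose of 20 mg/kg by the oral route (a higher number here means more inhibition at the dose given (going by the name of the read-out), a lower number less inhibition), for the three compounds measured so far:

compound 1, `Cc1ccc(C(=O)CCc2nnc(-c3ccccc3)o2)cc1`: 49.3%
compound 2, `Cc1ccc(C(=O)CCc2nnc(-c3ccc(Cl)cc3)o2)cc1`: 81.5%
compound 3, `Cc1ccc(C(=O)CCc2nnc(-c3ccc([N+](=O)[O-])cc3)o2)cc1`: 60.5%

Compound 1 carries no substituent on either of its two outer aromatic rings and gives the lowest of the three numbers in this assay. Its nearest neighbour is compound 3, a step described by a number 11.2 percentage points higher from compound 1 to compound 3 (beyond the scatter); the furthest is compound 2, reached by a number 32.2 percentage points higher from compound 1 to compound 2 (beyond the scatter). Between those two substituted compounds, the step of a number 21 percentage points lower from compound 2 to compound 3 (beyond the scatter) separates them.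

Compound 4, `Cc1ccc(C(=O)CCc2nnc(-c3ccccc3)o2)c(C)c1`, differs from compound 1 in one place: methyl in place of hydrogen on an aromatic carbon. The new group sits on the ring that already bears a methyl group, not on the ring where compound 2 and compound 3 were varied. The measured steps therefore do not touch the same place; they only show that a single small group added to compound 1 raised the number, by a large amount in one case and a modest amount in the other. Among the measured compounds shown here, with no direct precedent for this ring, a small rise or a change within the usual scatter seems the most reasonable expectation for this assay.

Compound 4 is therefore estimated at 55%, within a range of 40% to 70%, which would mean an expected step of a number 5.7 percentage points higher from compound 1 to compound 4 (within the scatter).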

Compound 4, a percentage reported as inhibition, in the whole organism at one dose (the size of the read-out at that dose, not a potency): 58%
For compound 4 the middle estimate is 3 percentage points below the measured one; low and high end bracket the measured number.
By their numbers in this assay, from the lowest: compounds 1, 4 and 3 (each within the scatter of the next, the first and the last beyond it); then compound 2.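

Among the compounds shown here, this is the first change on the ring that already bears a methyl group, since the earlier steps all lay on the other outer ring. A second methyl, placed on an aromatic carbon ortho to a large group and meta to the existing methyl group, gives a number 8.7 percentage points higher from compound 1 to compound 4 (within the scatter) in this assay, so this single change cannot be told apart from no change in this read-out, and the position accepts this one-carbon group without a clear loss or gain at the dose given. Nothing available explains this result, and a single group at a single place cannot show how the position responds to other groups.

The compounds shown leave open whether a chloro group, a nitro group, an amine or a carboxylic acid at this same place would move the number beyond the scatter, as chloro and nitro did on the other ring, and whether a longer chain such as ethyl would behave like methyl. They also leave open whether this second methyl could be combined with the chloro group of compound 2 while keeping that compound's value of 81.5%.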